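A few compounds are considered here, and "the series" means these few. Any claim that something is new, unique, unknown or untested is made for them only; others in the source may bear on it.

Measured compounds:
compound 1, `CC1=C(C(=O)CC(C)C)C(c2cccs2)NC(=O)N1`, 19% in an assay on membranes from CHO cells for displacement of a labelled ligand from adenosine receptor A1 (Homo sapiens), read by scintillation counting, with a stated time of 60 min, tested at 1 uM; on this read-out higher numbers stand for more inhibition at the one concentration tested (going by the name of the read-out) and lower numbers for less inhibition
compound 2, `CCSC(=O)C1=C(C)NC(=O)NC1c1cccs1`, 6%

Within the data shown here, compound 2 stands lowest of the two numbers in this assay; its nearest neighbour is compound 1, and the one step that connects them, a number 13 percentage points lower from compound 1 to compound 2 (beyond the scatter), is the sole comparison available. That step swapped ethylsulfanyl for isobutyl on a carbonyl carbon, and it is not the change that now follows. Compound 3, `CC1=C(c2ncc(C)o2)C(c2cccs2)NC(=O)N1`, differs from compound 2 in this way: 5-methyl-1,3-oxazol-2-yl in place of (ethylsulfanyl)carbonyl on a double-bonded ring carbon. Among the measured compounds shown here, the whole (ethylsulfanyl)carbonyl departs and 5-methyl-1,3-oxazol-2-yl arrives on the double-bonded ring carbon, so no measured step bears on it directly. For the measured compounds named here, with the only reading of the shared core sitting at a low level in compound 2 and no guide for this exchange, a small rise at most is expected, within or just beyond the scatter, as a number 6 percentage points higher from compound 2 to compound 3 (within the scatter). Compound 3 is therefore estimated at 12%, between 0% and 35%.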

Compound 3, a percentage reported as inhibition, at one concentration (the size of the read-out at that concentration, not a potency): 21%
For compound 3 the middle estimate is 9 percentage points below the measured one, and the stated range covers the measured number.
By their numbers in this assay, from the lowest: compound 2; then compounds 1 and 3 (each within the scatter of the next).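

Replacing (ethylsulfanyl)carbonyl with 5-methyl-1,3-oxazol-2-yl on the double-bonded ring carbon gives a number 15 percentage points higher from compound 2 to compound 3 (beyond the scatter) in this assay and shows that this position can carry a five-membered aromatic ring in place of a carbonyl-linked group. Set against isobutylcarbonyl, the same ring gives a number 2 percentage points higher from compound 1 to compound 3 (within the scatter) and cannot be told apart from it, so a carbonyl on this carbon is not required for a reading at this level. Compound 2 alone stands apart from the other two, and no measurement shown accounts for that.

On these data alone, it remains open whether an amine, a carboxylic acid or a longer chain on this carbon would lift the inhibition further. Also unresolved is what the methyl group on the oxazole contributes, and how the thiophen-2-yl group bears on any of these readings.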